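Moving the chlorine: 4-chlorophenyl to 3-chlorophenyl

The source may hold more compounds than are shown below. What is called first, only, known or untested is meant among the compounds shown, and "the series" means these compounds.

In a functional assay on HepG2 cells (Homo sapiens) for antiproliferative activity, read by MTT assay, with a stated time of 48 h (a lower number here means a stronger inhibitor, a higher number a weaker inhibitor), compound 1 (`O=C(Nc1ccccc1)Nc1cccc(CNc2nccnc2Cl)c1`) gives 15600 nM and compound 2 (`O=C(Nc1ccc(Cl)cc1)Nc1cccc(CNc2nccnc2Cl)c1`) gives 8350 nM with the two values lying within the scatter of each other. Compound 3 (`O=C(Nc1cccc(Cl)c1)Nc1cccc(CNc2nccnc2Cl)c1`) is unmeasured and carries 3-chlorophenyl in place of 4-chlorophenyl on an amide-type nitrogen. Among the compounds with values here, the only measured step that bears on this is a 1.9-fold lower number from compound 1 to compound 2 (0.27 log units; within the scatter) and no measured pair yet shows the chloro group changing place. A step beyond the scatter in this assay is therefore not expected, and the estimated step stays small (a 1.2-fold higher number from compound 2 to compound 3 (0.08 log units; within the scatter)). The estimated value for compound 3 is 10000 nM with an expected range (4500 nM to 22000 nM).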

Compound 3, half-maximal inhibitory concentration: 9140 nM
Estimate against measurement, compound 3: 1.1-fold (0.04 log units) above; low and high end bracket the measured number.
By their numbers in this assay, from the lowest: compounds 2, 3 and 1 (each within the scatter of the next).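

In this assay, the chloro group changing place now has a measured step: 3-chlorophenyl in place of 4-chlorophenyl on the amide-type nitrogen (a 1.1-fold higher number from compound 2 to compound 3 (0.04 log units; within the scatter)). Chloro in place of hydrogen also stays within the scatter with the chlorine in its new place (a 1.7-fold lower number from compound 1 to compound 3 (0.23 log units; within the scatter)), so neither chlorinated compound separates from compound 1. Nothing at hand gives a reason for these steps.

Open, going by these compounds, is whether any other group on this phenyl ring can produce a step beyond the scatter. A methoxy group, an amine or a carboxylic acid in place of the chlorine would test this.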